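A few compounds are considered here, and "the series" means these few. Any claim that something is new, unique, unknown or untested is made for them only; others in the source may bear on it.

Measured in an ADME assay for permeability, using PAMPA, at pH 7.4; on this read-out higher numbers stand for higher permeability and lower numbers for lower permeability:

- compound 1 `Cc1cc(NC(=O)Nc2ccc(C(C)(C)C)cc2)c2ccccc2n1`: 142 10^-6 cm/s
- compound 2 `CSc1ccc(NC(=O)Nc2cc(C)nc3ccccc23)cc1`: 473 10^-6 cm/s
- compound 3 `CC(=O)c1ccc(NC(=O)Nc2cc(C)nc3ccccc23)cc1`: 473 10^-6 cm/s

Compound 3 shares the top of this small set with compound 2. The numbers show no change at the digits printed from compound 2 to compound 3 (within the scatter) and also a 3.3-fold higher number from compound 1 to compound 3 (0.52 log units; beyond the scatter), so only compound 1 stands apart.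

The unmeasured compound 4 `Cc1ccc(NC(=O)Nc2cc(C)nc3ccccc23)cc1` carries a single change: methyl in place of acetyl on an aromatic carbon. In words, this is methyl in place of acetyl on an aromatic carbon, para to a large group. Among the compounds with values here, no measured compound carries methyl there, so the nearest evidence comes from other swaps of this group. Within the data shown here, the data show a 3.3-fold higher number from compound 1 to compound 2 (0.52 log units; beyond the scatter), a modest step, and no change at the digits printed from compound 2 to compound 3 (within the scatter), which is no step at all. Only the swaps away from tert-butyl went beyond the scatter, and tert-butyl plays no part in this change. No step beyond the scatter is therefore expected in this assay. The step is expected to be a 1.2-fold lower number from compound 3 to compound 4 (0.07 log units; within the scatter), a small one. For compound 4 the estimated value is 400 10^-6 cm/s, with an expected range from 180 10^-6 cm/s to 800 10^-6 cm/s.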

Compound 4, apparent permeability: 669 10^-6 cm/s
For compound 4 the middle estimate is 1.7-fold (0.22 log units) below the measured one, and the stated range covers the measured number.
By their numbers in this assay, from the lowest: compound 1; then compounds 2, 3 and 4 (each within the scatter of the next).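

In this assay, methyl at this place, para to a large group, reads level with the larger acetyl, with a 1.4-fold higher number from compound 3 to compound 4 (0.15 log units; within the scatter), and with methylsulfanyl, with a 1.4-fold higher number from compound 2 to compound 4 (0.15 log units; within the scatter). Compounds 2, 3 and 4 therefore form one cluster despite their different groups, and now three swaps away from tert-butyl go beyond the scatter, the latest being a 4.7-fold higher number from compound 1 to compound 4 (0.67 log units; beyond the scatter). Nothing at hand explains why compound 1 stands apart from the other three.

As far as these compounds go, whether an amine, a carboxylic acid or a longer chain at this place would stay with the cluster or fall toward compound 1 remains open. So does the fate of isopropyl, a smaller branched relative of tert-butyl, which would help show how much of a change this cluster tolerates.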